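The source may report more compounds than this note shows. Statements on the series, on what has been measured and on what is new or still open speak of the compounds shown alone.

Measured so far:
compound 1 `CC(C)[C@H](NC(=O)c1cc(Cl)ccc1OCCN)C(=O)Nc1ccc([N+](=O)[O-])cc1Cl`: > 10000 nM
compound 2 `C[C@H](NC(=O)c1cc(Cl)ccc1OCCN)C(=O)Nc1ccc([N+](=O)[O-])cc1Cl`: > 10000 nM
compound 3 `CSCC[C@H](NC(=O)c1cc(Cl)ccc1OCCN)C(=O)Nc1ccc([N+](=O)[O-])cc1Cl`: > 10000 nM

All three readings come from a functional assay on MDA-MB-231 cells (Homo sapiens) for inhibition, read by MTT assay, with a stated time of 72 h; on this read-out lower numbers stand for stronger inhibition and higher numbers for weaker inhibition. Compound 1 gives > 10000 nM, which is a limit of the assay and not a number. The same holds across the set, with the limit of > 10000 nM in this assay, at which 3 of the 3 values shown sit.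

Compound 4 `CC(C)[C@H](NC(=O)c1cc(Cl)ccc1OCCN)C(=O)Nc1ccc(F)c(F)c1` keeps the core of compound 1 and changes one group: 3,4-difluorophenyl in place of 2-chloro-4-nitrophenyl on an amide-type nitrogen.

Three measured steps are available: a step that the two limits leave unreadable from compound 1 to compound 2, then a step that the two limits leave unreadable from compound 1 to compound 3, and finally a step that the two limits leave unreadable from compound 2 to compound 3. Each swaps a group on a saturated chain carbon, not on the amide-type nitrogen, and none has a readable size. They therefore give no measure for the new change. Only a modest move toward stronger inhibition is expected, and another reading at the limit remains quite possible.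

The expected change is an at least 1.4-fold lower number from compound 1 to compound 4 (0.15 log units; that floor lies within the scatter). Compound 4 is estimated at 7000 nM, with an expected range from 2000 nM to 20000 nM.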

Compound 4, half-maximal inhibitory concentration: > 10000 nM
Compound 4 gave a limit, no number (the forecaster's own chance of this, stated with the estimate: 45%); middle value at least 1.4-fold (0.15 log units) from the limit.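

Compound 4, like compound 1, gives a limit and not a number, so no size can be read for the step between them. The compounds shown leave open whether any of these group changes alters inhibition at all, because every reading stops at the same point: the limit of > 10000 nM in this assay, at which 4 of the 4 values shown sit.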